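Adding one methyl to an isopropyl amide

A few compounds are considered here, and "the series" means these few. Any claim that something is new, unique, unknown or untested is made for them only; others in the source may bear on it.

Compound 1 `CN(C)C(=O)CCC(=O)c1cccc(C(F)(F)F)c1` gives > 50 mg/kg
Compound 2 `CC(C)NC(=O)CCC(=O)c1cccc(C(F)(F)F)c1` gives > 200 mg/kg

In a functional assay on the whole organism with Mus musculus as the target (a lower number here means that less compound is needed, a higher number that more compound is needed for the effect), compound 2 gives > 200 mg/kg as its result, and this is a limit of the assay, not a number. Compound 1 gives > 50 mg/kg in this assay as its result, which is also a limit. Compound 2 therefore has no true number to stand on, and the only other result offers none either.

Compound 3 `CCC(C)NC(=O)CCC(=O)c1cccc(C(F)(F)F)c1` keeps the shared core and alters the amide side chain, with the change methyl in place of hydrogen on a saturated chain carbon, two bonds along the chain from an amide-type nitrogen in the structure. Cut one bond further out, this is isopropyl to sec-butyl.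

Among the measured compounds shown here, the only measured step that bears on this change is a step that the two limits leave unreadable from compound 1 to compound 2 in the same part of the molecule. It has no readable size, so it gives no guide to direction. No step beyond the usual scatter is therefore expected in this assay for this change. The expected step is a number no higher from compound 2 to compound 3 (the limit leaves the size open) on this estimate. Compound 3 is estimated at 200 mg/kg within an expected range of 70 mg/kg to 500 mg/kg as its result, though another limit would be no surprise.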

Compound 3, dose for half-maximal effect: > 200 mg/kg
Compound 3: a limit, no number; the forecaster's own chance of this, stated with the estimate: 55%; the middle value sits exactly at the limit.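

Among the compounds shown here, compound 1, compound 2 and compound 3 all end on limits of the assay rather than true numbers, so no step between them can be read: the limit of > 200 mg/kg in this assay, at which 2 of the 3 values shown sit. The compounds shown leave open what dose of any of them gives the half-maximal effect in this assay, and whether changing the amide side chain shifts that dose at all.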